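The source may report more compounds than this note shows. Statements on the series, on what has been measured and on what is new or still open speak of the compounds shown alone.

Measured so far:
- compound 1 `Fc1ccc(CCCc2sc3ncccc3c2-c2ccc(F)cc2)cc1`, in an assay on cell membranes for displacement of a labelled ligand from metabotropic glutamate receptor 5 (Rattus norvegicus), tested at 1 uM (a lower number here means less inhibition, a higher number more inhibition at the concentration tested (going by the name of the read-out)), compound 1 gives 0%
- compound 2 `c1ccc(-c2csc3ncccc23)cc1`, in this assay compound 2 gives 0%

Compound 1 and compound 2 thus stand level with each other in this assay, within the usual scatter of this kind of measurement, so neither shows any inhibition at the concentration tested. The piece follows the step from compound 1 to the unmeasured compound 3 `OC(CCc1ccc(F)cc1)c1sc2ncccc2c1-c1ccc(F)cc1`. The change is hydroxy in place of hydrogen on a saturated chain carbon bound to an aromatic carbon and a saturated chain carbon. Going by the values given here, no step between two measured compounds is available to guide the expectation, so the step from compound 1 to compound 3 in this assay is expected to be small, a number 5 percentage points higher from compound 1 to compound 3 (within the scatter), with no firm direction beyond the scatter. Compound 3 is accordingly expected to give about 5%, in a range from 0% to 25%.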

Compound 3, a percentage reported as inhibition, at one concentration (the size of the read-out at that concentration, not a potency): 3%
Estimate against measurement, compound 3: 2 percentage points above; the range from low to high includes it.
By their numbers in this assay, from the lowest: compounds 1, 2 and 3 (each within the scatter of the next).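

In this assay hydroxy in place of hydrogen on this saturated chain carbon gives a number 3 percentage points higher from compound 1 to compound 3 (within the scatter) and so leaves the read-out where it was, within the scatter. At the concentration tested, this single added group on the chain does not bring out any clear inhibition in a compound that showed none. Nothing available bears on why this is so. Going by these compounds, whether a carbonyl or an amine on the same carbon would give a different read-out remains open, as does the effect of a longer chain.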